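The source may report more compounds than this note shows. Statements on the series, on what has been measured and on what is new or still open speak of the compounds shown alone.

In an ADME assay on L929 cells (Mus musculus) for cytotoxicity, read by resazurin assay, with a stated time of 48 h (on this read-out lower numbers stand for higher toxicity in this test and higher numbers for lower toxicity in this test), compound 1 (`O=c1c2cc([N+](=O)[O-])ccc2n(CCCBr)n1Cc1ccccc1`) gives 25200 nM and compound 2 (`CCOC(=O)CCCn1c2ccc([N+](=O)[O-])cc2c(=O)n1Cc1ccccc1`) gives 78100 nM while compound 3 (`CCOC(=O)n1c2ccc([N+](=O)[O-])cc2c(=O)n1Cc1ccccc1`) gives 122000 nM on the same read-out. Compound 3 stands level with compound 2 (a 1.6-fold higher number from compound 2 to compound 3 (0.19 log units; within the scatter)) and apart from compound 1 (a 4.8-fold higher number from compound 1 to compound 3 (0.68 log units; beyond the scatter)).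

Next in the series is compound 4 (`Cc1ccc(S(=O)(=O)n2c3ccc([N+](=O)[O-])cc3c(=O)n2Cc2ccccc2)cc1`), which has (4-methylphenyl)sulfonyl in place of ethoxycarbonyl on an aromatic nitrogen. For the measured compounds named here, no measured compound carries this group, so no step tests it directly. The nearest guides are the two steps above, both changes on that same aromatic nitrogen, along with the change at the end of the chain (a 3.1-fold higher number from compound 1 to compound 2 (0.49 log units; beyond the scatter)). Going by the values given here, these steps are modest or within the scatter, and only three compounds stand behind them. A large move is therefore not expected. With compound 3 at the upper end of the measured values, the lean is towards a lower number, but no step beyond the scatter is expected. The expected change is a 1.5-fold lower number from compound 3 to compound 4 (0.18 log units; within the scatter) on this estimate. For compound 4 the estimated value in this assay is 80000 nM (expected range 30000 nM to 200000 nM).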

Compound 4, concentration lethal to 50% of the cells: > 256000 nM
Compound 4 was reported as a limit (the forecaster's own chance of this, stated with the estimate: 15%); middle value at least 3.2-fold (0.50 log units) away from the limit.
By their numbers in this assay, from the lowest: compound 1; then compounds 2 and 3 (each within the scatter of the next). At a limit, above all of these: compound 4.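

In this assay the value of compound 4 is a limit and not a number: the limit of > 256000 nM in this assay, at which 1 of the 4 values shown sits. With (4-methylphenyl)sulfonyl on the aromatic nitrogen, all three new steps lie beyond the scatter and all run the same way: an at least 2.0-fold higher number from compound 3 to compound 4 (0.32 log units; beyond the scatter), an at least 3.2-fold higher number from compound 2 to compound 4 (0.51 log units; beyond the scatter) and an at least 10-fold higher number from compound 1 to compound 4 (1.00 log units; beyond the scatter). For the compounds shown here, the earlier change between the two ester-bearing groups on this nitrogen stayed within the scatter (a 1.6-fold higher number from compound 2 to compound 3 (0.19 log units; within the scatter)), so compound 4 is the first sign that a change at this position can carry a compound clear of both compound 2 and compound 3, towards lower toxicity in this test, though each of these steps gives only a lower bound on the size of the change.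

The compounds shown do not separate the contribution of the sulfonyl link from that of the 4-methylphenyl ring, and a methylsulfonyl or a benzoyl group on the same nitrogen would address this. They also leave open whether the step holds when the benzyl group is replaced, for example by a simple methyl group.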